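Removing the N-aryl group from a limit compound

The source may hold more compounds than are shown below. What is called first, only, known or untested is meant among the compounds shown, and "the series" means these compounds.

Measured in a functional assay on HeLa cells (Homo sapiens) for antiproliferative activity, read by MTT assay, with a stated time of 72 h (a higher number here means a weaker inhibitor, a lower number a stronger inhibitor), so far
compound 1 `COc1ncc(-c2ccc3c(c2)NC(=O)CO3)cc1NS(=O)(=O)c1ccc(F)cc1` gives 7110 nM
compound 2 `O=C1COc2ccc(-c3cnc(Cl)c(NS(=O)(=O)c4ccc(F)cc4)c3)cc2N1c1ccc(F)cc1` gives > 40000 nM

Compound 2 stands at the limit of > 40000 nM in this assay, at which 1 of the 2 values shown sits, and so has a limit, not a number.

Compound 3 `O=C1COc2ccc(-c3cnc(Cl)c(NS(=O)(=O)c4ccc(F)cc4)c3)cc2N1` has hydrogen in place of 4-fluorophenyl on an amide-type nitrogen in a ring, as counted in hydrogen in place of 4-fluorophenyl on an amide-type nitrogen in a ring and with the rest of compound 2 unchanged.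

Within the data shown here, no measured step isolates this change. Compound 1 also carries hydrogen on that nitrogen, though it differs elsewhere, and the expectation rests on compound 1 at 7110 nM as the only numeric anchor. A move towards stronger inhibition in this assay is therefore expected, beyond the usual scatter, and the estimate is an at least 4.4-fold lower number from compound 2 to compound 3 (0.64 log units; beyond the scatter) as the expected step.

Compound 3 is estimated at 9000 nM with an expected range from 2500 nM to 32000 nM in this series.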

Compound 3, half-maximal inhibitory concentration: 15600 nM
Beside the measured number, compound 3's estimate is 1.7-fold (0.24 log units) below it; the range from low to high includes it.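

In this assay, compound 2 has a limit and not a number: the limit of > 40000 nM in this assay, at which 1 of the 3 values shown sits. Hydrogen in place of 4-fluorophenyl on the amide-type nitrogen gives an at least 2.5-fold lower number from compound 2 to compound 3 (0.40 log units; beyond the scatter) and brings this position back to a measured number, with the full size of the step open on one side. With hydrogen on that nitrogen in both compounds, chloro in place of methoxy on an aromatic carbon can now be read as a single change, and it gives a 2.2-fold higher number from compound 1 to compound 3 (0.34 log units; beyond the scatter) as a modest step.

The compounds shown leave open whether methyl or a longer chain on the amide-type nitrogen keeps the number of compound 3 or moves it towards the limit. Also open, as far as these compounds go, is how an amine or a nitrile in place of chloro on that aromatic carbon would read.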